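Removing an ethyl from the shared core of compound 1

The source may report more compounds than this note shows. Statements on the series, on what has been measured and on what is new or still open speak of the compounds shown alone.

Compound 1 `CCCC[C@]1(CC)CS(=O)(=O)c2ccc(N)cc2[C@@H](c2ccccc2)[C@H]1O` gives 68 nM in an assay on cells for inhibition of ileal sodium/bile acid cotransporter (Homo sapiens) (a lower number here means a stronger inhibitor, a higher number a weaker inhibitor), the lowest of the three numbers recorded. Compound 2 `CCCC[C@]1(CC)CS(=O)(=O)c2ccc(N(O)C(=O)OC(C)(C)C)cc2[C@@H](c2ccccc2)[C@H]1O` gives 2670 nM and compound 3 `CCCC[C@]1(CC)CS(=O)(=O)c2ccc(NC(=O)OCc3ccccc3)cc2[C@@H](c2ccccc2)[C@H]1O` gives 400 nM; both steps, a 39-fold higher number from compound 1 to compound 2 (1.59 log units; beyond the scatter) and a 5.9-fold higher number from compound 1 to compound 3 (0.77 log units; beyond the scatter), change the substituent on the aromatic nitrogen, while a 6.7-fold lower number from compound 2 to compound 3 (0.82 log units; beyond the scatter) compares those two substituents. Compound 4 `CCC1(CC)CS(=O)(=O)c2ccc(N)cc2[C@@H](c2ccccc2)[C@H]1O` differs from compound 1 at another site: hydrogen in place of ethyl on a saturated chain carbon, two bonds along the chain from a saturated ring carbon. Going by the values given here, no measured step touches that saturated chain, so the measured steps say nothing directly about it. With no guidance, a modest weakening is expected for compound 4, giving a 2.9-fold higher number from compound 1 to compound 4 (0.47 log units; beyond the scatter), with a wide range. The estimate for compound 4 is 200 nM, between 50 nM and 800 nM.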

Compound 4, half-maximal inhibitory concentration: 4000 nM
The estimate for compound 4 lay 20-fold (1.30 log units) below the measured number; measured number outside the range, above it.
By their numbers in this assay, from the lowest: compound 1; then compound 3; then compounds 2 and 4 (each within the scatter of the next).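

In this assay, hydrogen in place of ethyl on this saturated chain carbon, two bonds along the chain from a saturated ring carbon, gives a 59-fold higher number from compound 1 to compound 4 (1.77 log units; beyond the scatter) and so counts as a large step. The change removes only two carbons and no hydrogen-bond donor or acceptor, yet the number depends strongly on this chain as well as on the substituent on the aromatic nitrogen. Nothing available here accounts for the size of this step.

The compounds shown leave open how the number would respond to a propyl or pentyl chain at this site. They also leave open whether an amine or a carboxylic acid at the end of the chain would be tolerated.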